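Benzyloxycarbonyl in place of methyl on the shared core

The source may report more compounds than this note shows. Statements on the series, on what has been measured and on what is new or still open speak of the compounds shown alone.

Compound 1 `O=C(OCc1ccccc1)c1ccc2[nH]c(-c3cn(-c4ccccc4)nc3-c3ccc(F)cc3)nc2c1` gives 9240 nM as its value
Compound 2 `COc1ccc(-c2nn(-c3ccccc3)cc2-c2nc3cc(Cl)ccc3[nH]2)cc1` gives 1760 nM as its value
Compound 3 `COc1ccc(-c2nn(-c3ccccc3)cc2-c2nc3cc(C)ccc3[nH]2)cc1` gives 6610 nM as its value

These values come from a functional assay on MCF7 cells (Homo sapiens) for antiproliferative activity, read by MTT assay, with a stated time of 48 h (on this read-out lower numbers stand for stronger inhibition and higher numbers for weaker inhibition), and there compound 3 lies within the scatter of compound 1 but clearly on the higher side of compound 2. Compound 4 `COc1ccc(-c2nn(-c3ccccc3)cc2-c2nc3cc(C(=O)OCc4ccccc4)ccc3[nH]2)cc1` has not yet been measured. Relative to compound 3 the change is benzyloxycarbonyl in place of methyl on an aromatic carbon with benzyloxycarbonyl in place of methyl on an aromatic carbon.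

Among the compounds with values here, one measured step touches this same carbon: a 3.8-fold higher number from compound 2 to compound 3 (0.57 log units; beyond the scatter) with methyl in place of chloro. That modest step shows that a swap here can move the number, so the range must stay wide. Within the data shown here, no measured step covers a group this large at this carbon. The closest evidence is compound 1 with 9240 nM as its value, which already carries benzyloxycarbonyl but has fluoro where compound 4 has methoxy. That value lies within the scatter of compound 3, so no large shift is expected.

In this assay the expected step is a 1.1-fold lower number from compound 3 to compound 4 (0.04 log units; within the scatter) and so none beyond the scatter. For compound 4 the estimated value is 6000 nM with an expected range from 2200 nM to 16000 nM as the likely span.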

Compound 4, half-maximal inhibitory concentration: 7460 nM
Beside the measured number, compound 4's estimate is 1.2-fold (0.09 log units) below it; the range from low to high includes it.
By their numbers in this assay, from the lowest: compound 2; then compounds 3, 4 and 1 (each within the scatter of the next).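

In this assay, the exchange of methyl for the much larger benzyloxycarbonyl, which brings its own six-membered aromatic ring and a double bond outside that ring, gives (a 1.1-fold higher number from compound 3 to compound 4 (0.05 log units; within the scatter)), so on this aromatic carbon the number tolerates a large change in the substituent. Chloro stays apart from this larger group (a 4.2-fold higher number from compound 2 to compound 4 (0.63 log units; beyond the scatter)), so among the three groups shown at this carbon with methoxy held constant, compound 2 alone has a number clearly lower than the others, while methyl and benzyloxycarbonyl cannot be told apart. With benzyloxycarbonyl in place, the exchange of fluoro for methoxy at the other site gives (a 1.2-fold lower number from compound 1 to compound 4 (0.09 log units; within the scatter)), so that exchange does not separate the pair either.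

The compounds shown leave open what an amine, a carboxylic acid, a bromo group or a shorter ester such as methoxycarbonyl would give on this carbon, and whether chloro keeps its lower number when fluoro replaces methoxy. Nothing among the data offered accounts for the lower number of compound 2 or for the flat response to the larger group.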